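Swapping trifluoromethyl for isopropyl on the oxadiazole tail

A few compounds are considered here, and "the series" means these few. Any claim that something is new, unique, unknown or untested is made for them only; others in the source may bear on it.

Three measured compounds share a core and were tested in a functional assay on MIA PaCa-2 cells (Homo sapiens) for inhibition, read by MTT assay, with a stated time of 3 days; on this read-out lower numbers stand for stronger inhibition and higher numbers for weaker inhibition. Compound 1 `CCCN(CCC)S(=O)(=O)c1ccc(S(=O)(=O)N2CCC[C@@H](C(=O)OCC)C2)cc1` gives 600 nM, compound 3 `CCOC(=O)[C@@H]1CCCN(S(=O)(=O)c2ccc(S(=O)(=O)N(CC)CC)c(F)c2)C1` gives 200 nM, and compound 2 `CCN(CC)S(=O)(=O)c1ccc(S(=O)(=O)N2CCC[C@@H](C(=O)N3CCN(c4nc(C(F)(F)F)no4)CC3)C2)cc1` gives 60 nM. Compound 2 therefore shows the lowest number of the three, with both compound 3 and compound 1 beyond the usual scatter above it, so it counts as the most potent of this set.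

Compound 4 `CCN(CC)S(=O)(=O)c1ccc(S(=O)(=O)N2CCC[C@@H](C(=O)N3CCN(c4nc(C(C)C)no4)CC3)C2)cc1` is not yet measured. It differs from compound 2 only at the tail: isopropyl in place of trifluoromethyl on an aromatic carbon. Within the data shown here, no measured pair shows what this change does. The expectation is a small step, a 1.5-fold higher number from compound 2 to compound 4 (0.18 log units; within the scatter), at most a mild weakening and possibly none beyond the scatter. Compound 4 is therefore estimated at 90 nM, within 30 nM to 270 nM.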

Compound 4, half-maximal inhibitory concentration: 30 nM
For compound 4 the middle estimate is 3.0-fold (0.48 log units) above the measured one; the measured number falls inside the stated range.
By their numbers in this assay, from the lowest: compounds 4 and 2 (each within the scatter of the next); then compound 3; then compound 1.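

In this assay, this aromatic carbon accepts isopropyl in place of trifluoromethyl, with a 2.0-fold lower number from compound 2 to compound 4 (0.30 log units; within the scatter), so the two tails cannot be told apart on this read-out. Among these compounds, this is the first direct look at the position, and it shows that the fluorine atoms of compound 2 are not needed for a number this low. Nothing measured here explains why the two tails read alike. Open, going by these compounds, is what a smaller methyl, a larger tert-butyl, a cyclopropyl ring or an amine would do on this same carbon.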